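Methyl on the Chain Carbon Beside the Amide Nitrogen

A few compounds are considered here, and "the series" means these few. Any claim that something is new, unique, unknown or untested is made for them only; others in the source may bear on it.

Compound 1 `COc1ccc(C(=C/C=C/C(=O)NCCCCc2cccnc2)c2ccc(OC)c(OC)c2)cc1OC` gives, in a functional assay with platelet-activating factor receptor (Cavia porcellus) as the target (on this read-out higher numbers stand for an effect only at larger amounts of compound and lower numbers for an effect already at smaller amounts), a value of 0.54 mg/kg. Compound 3 `COc1ccc(C(=C/C=C/C(=O)N[C@H](C)CCCc2cccnc2)c2ccc(OC)c(OC)c2)cc1OC` differs from it by methyl in place of hydrogen on a saturated chain carbon bound to an amide-type nitrogen and a saturated chain carbon, and in this assay compound 3 gives 0.14 mg/kg, a step of a 3.9-fold lower number from compound 1 to compound 3 (0.59 log units; beyond the scatter). Compound 2 `O=C(/C=C/C=C(c1cccc(F)c1)c1cccc(F)c1)NCCCCc1cccnc1` rests on a different core; how the two cores differ is not broken down here, and in this assay compound 2 gives 0.34 mg/kg. Compound 4 `C[C@H](CCCc1cccnc1)NC(=O)/C=C/C=C(c1cccc(F)c1)c1cccc(F)c1` carries the same change on the core of compound 2, namely (methyl in place of hydrogen on a saturated chain carbon bound to an amide-type nitrogen and a saturated chain carbon). Within the data shown here, since the change from compound 1 to compound 3 gave a 3.9-fold lower number from compound 1 to compound 3 (0.59 log units; beyond the scatter), a step of similar size is expected, a 2.8-fold lower number from compound 2 to compound 4 (0.45 log units; beyond the scatter), with the single precedent as the only basis. Compound 4 is therefore estimated at 0.12 mg/kg in this assay, between 0.05 mg/kg and 0.3 mg/kg.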

Compound 4, dose for 50% inhibition: 0.22 mg/kg
For compound 4 the middle estimate is 1.8-fold (0.26 log units) below the measured one; the measured number falls inside the stated range.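

Carried to the second core, methyl in place of hydrogen gives a 1.5-fold lower number from compound 2 to compound 4 (0.19 log units; within the scatter) in this assay, so on that core alone the change shows no clear effect. The two steps cannot be told apart: the same change on two cores in this assay, a 3.9-fold lower number (0.59 log units; beyond the scatter) from compound 1 to compound 3 and a 1.5-fold lower number (0.19 log units; within the scatter) from compound 2 to compound 4, 2.5-fold (0.40 log units) apart, within the scatter of two such steps The result is thus compatible with the change carrying over between these two cores, but it does not show that it does, nor that the step has the same size on both.

The compounds shown leave open how an ethyl group in place of the methyl, or the opposite configuration at that chain carbon, would fare on either core. They also leave open whether the step would hold on a core bearing other groups, such as chloro or trifluoromethyl.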